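Swapping the nitrophenyl for a fluorophenyl on the chain carbon

The source may hold more compounds than are shown below. What is called first, only, known or untested is meant among the compounds shown, and "the series" means these compounds.

Within the data shown here, compound 2 `N/C(=N/NC(CC(=O)c1ccc(-n2ccnc2)cc1)c1ccc([N+](=O)[O-])cc1)c1ccccn1` has the lowest of the two numbers measured so far in an ADME assay on Vero cells (Chlorocebus sabaeus) for cytotoxicity, read by MTT assay, with a stated time of 72 h (on this read-out higher numbers stand for lower toxicity in this test and lower numbers for higher toxicity in this test), giving 23100 nM, while compound 1 `N/C(=N/NC(CC(=O)c1ccc(-n2ccnc2)cc1)c1ccccc1Cl)c1ccccn1` gives 53200 nM in this assay. Compound 3 `N/C(=N/NC(CC(=O)c1ccc(-n2ccnc2)cc1)c1ccccc1F)c1ccccn1` carries 2-fluorophenyl in place of 4-nitrophenyl on a saturated chain carbon bound to an amine nitrogen and a saturated chain carbon. Among the measured compounds shown here, the only measured step that bears on this is a 2.3-fold lower number from compound 1 to compound 2 (0.36 log units; beyond the scatter), which ran in the opposite direction, a halogen giving way to the nitro group. Compound 3 is therefore expected to move back toward compound 1, and the estimated step is a 1.9-fold higher number from compound 2 to compound 3 (0.29 log units; within the scatter). For compound 3 the expected value in this assay is 45000 nM, within a range of 20000 nM to 100000 nM.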

Compound 3, half-maximal cytotoxic concentration: 62100 nM
Estimate against measurement, compound 3: 1.4-fold (0.14 log units) below; the measured number falls inside the stated range.
By their numbers in this assay, from the lowest: compound 2; then compounds 1 and 3 (each within the scatter of the next).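

Moving from 4-nitrophenyl to 2-fluorophenyl at this chain carbon gives a 2.7-fold higher number from compound 2 to compound 3 (0.43 log units; beyond the scatter) in this assay, which leaves compound 2 apart from both halogen-bearing compounds. Fluoro in place of chloro on the aromatic carbon gives a 1.2-fold higher number from compound 1 to compound 3 (0.07 log units; within the scatter), so this assay does not separate the two halogens here. No measurement on hand explains the gap.

The nitro and halogen groups also differ in where they sit on the phenyl ring, and the compounds shown leave open which difference counts. From the compounds shown here alone, how a plain phenyl or an amine-bearing phenyl would read also stays open.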